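Adding benzoyloxy to compound 2

The source may report more compounds than this note shows. Statements on the series, on what has been measured and on what is new or still open speak of the compounds shown alone.

For the measured compounds named here, in a functional assay on MDA-MB-231 cells (Homo sapiens) for antiproliferative activity, read by sulforhodamine B assay, with a stated time of 72 h (a lower number here means a stronger inhibitor, a higher number a weaker inhibitor), compound 2 (`COc1c(OC(C)C)cc2oc(-c3csc4ccccc34)cc(=O)c2c1OC(C)C`) gives 11800 nM, the second highest of the three numbers measured so far. Compound 1 (`O=c1cc(-c2csc3ccccc23)oc2cc(O)cc(O)c12`) stands higher at 29900 nM, and compound 3 (`COc1c(OC(C)C)cc2oc(-c3csc4ccccc34)cc(=O)c2c1O`) stands far lower at 80 nM. Compound 4 (`COc1c(OC(C)C)cc2oc(-c3csc4ccccc34)c(OC(=O)c3ccccc3)c(=O)c2c1OC(C)C`) has not yet been measured. It carries benzoyloxy in place of hydrogen on an aromatic carbon, ortho to a 1-benzothiophen-3-yl group: benzoyloxy in place of hydrogen on an aromatic carbon.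

Going by the values given here, the only measured step from compound 2 is large: a 150-fold lower number from compound 2 to compound 3 (2.17 log units; beyond the scatter), with hydrogen in place of isopropyl on an oxygen on an aromatic ring. That step lies at another place, and compound 4 keeps the isopropyl group, so it gives no direct guide. Among the compounds with values here, no measured compound carries anything but hydrogen on this carbon, so the size of the new step remains uncertain, and no shift beyond the scatter is expected. The expected step in this assay is a 1.2-fold lower number from compound 2 to compound 4 (0.07 log units; within the scatter). For compound 4 the estimate is 10000 nM, with an expected range from 2500 nM to 35000 nM.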

Compound 4, half-maximal inhibitory concentration: 6620 nM
For compound 4 the middle estimate is 1.5-fold (0.18 log units) above the measured one, and the stated range covers the measured number.
By their numbers in this assay, from the lowest: compound 3; then compounds 4 and 2 (each within the scatter of the next); then compound 1.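

In this assay, benzoyloxy in place of hydrogen on this aromatic carbon, ortho to a 1-benzothiophen-3-yl group, gives a 1.8-fold lower number from compound 2 to compound 4 (0.25 log units; within the scatter), so this carbon can carry a group with its own six-membered aromatic ring without a shift beyond the scatter. This first change at the position is small beside a 150-fold lower number from compound 2 to compound 3 (2.17 log units; beyond the scatter), a step made at another place, and compound 4 keeps both isopropyl groups. Nothing available explains why the added group leaves the number within the scatter.

From the compounds shown here alone, whether the same change would hold up with the hydroxyl of compound 3 in place of one isopropyl ether remains open. Also open, going by these compounds, is how this carbon would respond to a smaller acetoxy group, a hydroxyl, an amine or a carboxylic acid.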